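Swapping the Outer Ring of Compound 2

The compounds below may be only part of what the source reports. "The series", "measured", "known", "first", "only" and "open" are said of these compounds alone.

Compound 1 `Fc1ccc(-c2ccc(-c3ccc(-c4nc5ccccc5[nH]4)cc3)cc2)cc1`: 100000 nM
Compound 2 `Oc1cccc2[nH]c(-c3ccc(-c4ccc(-c5ccc(F)cc5)cc4)cc3)nc12`: 6320 nM

Both were tested in a functional assay on ZR-75-1 cells (Homo sapiens) for inhibition, read by sulforhodamine B assay; on this read-out lower numbers stand for stronger inhibition of growth and higher numbers for weaker inhibition of growth. Among the measured compounds shown here, compound 2 stands lowest of the two numbers; the single measured step, a 16-fold lower number from compound 1 to compound 2 (1.20 log units; beyond the scatter), comes from a hydroxy in place of hydrogen on an aromatic carbon of the shared core.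

Compound 3 `COc1ccc(-c2ccc(-c3ccc(-c4nc5c(O)cccc5[nH]4)cc3)cc2)cc1OC` differs from compound 2 at the far end of the molecule: 3,4-dimethoxyphenyl in place of 4-fluorophenyl on an aromatic carbon. For the measured compounds named here, this change lies at a different place than the measured step, so no measured step bears on it directly. With nothing to guide the size, a step of modest size in either direction, or none beyond the scatter, is expected; the estimated step is a 1.1-fold lower number from compound 2 to compound 3 (0.02 log units; within the scatter). In this assay compound 3 is therefore expected to give about 6000 nM, within a wide range from 1200 nM to 30000 nM.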

Compound 3, concentration for 50% growth inhibition: 2110 nM
Estimate against measurement, compound 3: 2.8-fold (0.45 log units) above; the range from low to high includes it.
By their numbers in this assay, from the lowest: compound 3; then compound 2; then compound 1.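

The outer ring is not a silent part of the molecule: in this assay, 3,4-dimethoxyphenyl in place of 4-fluorophenyl gives a 3.0-fold lower number from compound 2 to compound 3 (0.48 log units; beyond the scatter), a modest step but one that exceeds the usual scatter. Among the compounds shown here, the earlier pair spoke only to the hydroxy on the shared core, so this is the first sign that the far end of the molecule also influences growth inhibition. No measurement at hand says why the number falls here.

As far as these compounds go, it remains open whether both methoxy groups are needed or a single methoxy group would give the same result, and whether an amine or a carboxylic acid on this ring would lower the number further. From the compounds shown here alone, it is also open whether the dimethoxy ring would give a similar step on a core without the hydroxy.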